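Chain-extended hydroxyl on the biphenyl sulfonamide series

The source may report more compounds than this note shows. Statements on the series, on what has been measured and on what is new or still open speak of the compounds shown alone.

Measured compounds:
compound 1 `O=S(=O)(Nc1cccc(CO)c1)c1ccc(-c2ccccc2)cc1`: 2200 nM
compound 2 `O=S(=O)(Nc1cccc(CO)c1)c1ccc(-c2ccc(Br)cc2)cc1`: 2500 nM
compound 3 `CS(=O)(=O)c1ccc(-c2ccc(S(=O)(=O)Nc3cccc(CO)c3)cc2)cc1`: a limit of the assay, > 5000 nM

All values come from a functional assay on J774 cells (Mus musculus) for cytotoxicity, read by resazurin assay, with a stated time of 72 h; a higher number here means a weaker inhibitor, a lower number a stronger inhibitor. In this assay compound 1 and compound 2 sit within the scatter of each other, so no order between them can be read. Compound 3 reaches only the limit of this assay and gives no number; the step of an at least 2.2-fold higher number from compound 1 to compound 3 (0.35 log units; beyond the scatter) is beyond the scatter, whereas an at least 2.0-fold higher number from compound 2 to compound 3 (0.30 log units; that floor lies within the scatter) has a floor that lies within it, and a 1.1-fold higher number from compound 1 to compound 2 (0.06 log units; within the scatter) is within the scatter.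

Compound 4 `O=S(=O)(Nc1cccc(CCO)c1)c1ccc(-c2ccc(Br)cc2)cc1` differs from compound 2 by hydroxymethyl in place of hydroxy on a saturated chain carbon bound to an aromatic carbon. Every measured step in the series changes a group on the distal aromatic ring; none touches the saturated chain carbon bound to the aromatic carbon on the sulfonamide side. Going by the values given here, no measured step therefore bears directly on this change, and nothing argues for a shift in either direction.

Compound 4 is expected to stay close to compound 2, with a step of no change at the digits printed from compound 2 to compound 4 (within the scatter) that is not expected to exceed the scatter. The estimate for compound 4 in this assay is 2500 nM, with a range from 1100 nM to 5500 nM.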

Compound 4, half-maximal inhibitory concentration: 5500 nM
Estimate against measurement, compound 4: 2.2-fold (0.34 log units) below; the measured number falls inside the stated range.
By their numbers in this assay, from the lowest: compounds 1 and 2 (each within the scatter of the next); then compound 4.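

In this assay, going by these compounds alone, the change from hydroxymethyl to 2-hydroxyethyl gives a 2.2-fold higher number from compound 2 to compound 4 (0.34 log units; beyond the scatter), the first reading at this position, and it shows that the saturated chain carbon bound to an aromatic carbon is not silent in this assay, since the step is modest but lies beyond the scatter. The earlier steps shown here all changed a group elsewhere on the core and could not show this; here the bromo is held constant, so the shift belongs to this one change, though a single pair sets no trend. Compound 3 remains the only member with a limit of the assay rather than a number, so the top of the readable range stays close at hand: the limit of > 5000 nM in this assay, at which 1 of the 4 values shown sits.

The compounds shown leave open whether the same shift appears when the bromo is replaced by hydrogen or methylsulfonyl, and they give no reason for the shift. They also leave open how this assay would respond to a longer chain at this position, or to an amine or a carboxylic acid in place of the terminal hydroxy.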